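Three Triazole Aryl Variants Near the Assay Ceiling

The source may hold more compounds than are shown below. What is called first, only, known or untested is meant among the compounds shown, and "the series" means these compounds.

Compound 3 `COc1ccccc1-n1nncc1CN1C(=O)C2(C(C#N)=C(N)Oc3c2c2nc4ccccc4nc2c2ccccc32)c2ccccc21` gives in a functional assay on A549 cells (Homo sapiens) for antiproliferative activity, read by MTT assay, with a stated time of 48 h (a lower number here means a stronger inhibitor, a higher number a weaker inhibitor), only a limit, > 50000 nM. Compound 2 `N#CC1=C(N)Oc2c(c3nc4ccccc4nc3c3ccccc23)C12C(=O)N(Cc1cnnn1-c1ccccc1Br)c1ccccc12` likewise returns only a limit, > 50000 nM. Compound 1 `N#CC1=C(N)Oc2c(c3nc4ccccc4nc3c3ccccc23)C12C(=O)N(Cc1cnnn1-c1ccccc1Cl)c1ccccc12` gives 42600 nM in this assay, and the limit of > 50000 nM in this assay, at which 2 of the 3 values shown sit, shows where the other two values sit. The measured changes are an at least 1.1-fold higher number from compound 1 to compound 2 (0.06 log units; that floor lies within the scatter), an at least 1.1-fold higher number from compound 1 to compound 3 (0.06 log units; that floor lies within the scatter) and a step that the two limits leave unreadable from compound 2 to compound 3, none of them readable as more than a small shift toward weaker inhibition. Among the measured compounds shown here, compound 4 `N#CC1=C(N)Oc2c(c3nc4ccccc4nc3c3ccccc23)C12C(=O)N(Cc1cnnn1-c1cccc(S(N)(=O)=O)c1)c1ccccc12` carries 3-sulfamoylphenyl in place of 2-methoxyphenyl on an aromatic nitrogen, a change that no measured step covers. With compound 3 already at the ceiling, compound 4 is expected to remain in the same weak region, with an at least 1.0-fold lower number from compound 3 to compound 4 (0.01 log units; that floor lies within the scatter), at an estimated 48000 nM within 15000 nM to 150000 nM, and a limit is the likelier outcome.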

Compound 4, half-maximal inhibitory concentration: 44200 nM
Compound 4: the middle estimate sits 1.1-fold (0.04 log units) above what was measured; the measured number falls inside the stated range.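

With 3-sulfamoylphenyl on the aromatic nitrogen, the number stays level with that of the 2-chlorophenyl compound, at a 1.0-fold higher number from compound 1 to compound 4 (0.02 log units; within the scatter). Thus a quite different aryl group at this place does not leave the weak region. The other two comparisons give only floors, an at least 1.1-fold lower number from compound 3 to compound 4 (0.05 log units; that floor lies within the scatter) and an at least 1.1-fold lower number from compound 2 to compound 4 (0.05 log units; that floor lies within the scatter), because compound 2 and compound 3 each rest on a limit: the limit of > 50000 nM in this assay, at which 2 of the 4 values shown sit.

Going by these compounds, it remains open whether any group at this place can bring strong inhibition. On these data alone, how a carboxylic acid or an amine on this phenyl ring, or a longer chain in its stead, would read is unknown.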